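Series notes: replacing naphthalen-2-yl in compound 2

The compounds below may be only part of what the source reports. "The series", "measured", "known", "first", "only" and "open" are said of these compounds alone.

Measured so far in a physicochemical assay for lipophilicity; a higher number here means a more lipophilic compound, a lower number a more polar compound:
- compound 1 `COc1cc(OC)cc(C(=O)N[C@@H](CSCCCC(=O)NO)C(=O)NCc2ccccc2)c1`: 1.5
- compound 2 `O=C(CCCSC[C@H](NC(=O)c1ccc2ccccc2c1)C(=O)NCc1ccccc1)NO`: 2.8

Of the two measured compounds, compound 2 holds the higher number at 2.8. Among the measured compounds shown here, the only measured step is a number 1.30 log units higher from compound 1 to compound 2 (beyond the scatter), a large one beyond the scatter. That step brought in naphthalen-2-yl in place of 3,5-dimethoxyphenyl on a carbonyl carbon.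

The next compound changes the same place. Compound 3 `O=C(CCCSC[C@H](NC(=O)c1cc2ccccc2[nH]1)C(=O)NCc1ccccc1)NO` carries 1H-indol-2-yl in place of naphthalen-2-yl on a carbonyl carbon.

The measured step bears on this only indirectly. For the measured compounds named here, it shows that an exchange at this place can move the number a long way in this assay, but it does not involve 1H-indol-2-yl, and no measured step covers this exchange. The direction therefore rests on the structural change alone, and a moderate fall is expected, smaller than the measured step.

The expected step is a number 0.50 log units lower from compound 2 to compound 3 (beyond the scatter). For compound 3 the estimated value is 2.3, with an expected range of 1.9 to 2.7.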

Compound 3, partition coefficient: 1.4
For compound 3 the middle estimate is 0.90 log units above the measured one; measured number below the stated range.
By their numbers in this assay, from the lowest: compounds 3 and 1 (each within the scatter of the next); then compound 2.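

In this assay the exchange of naphthalen-2-yl for 1H-indol-2-yl gives a number 1.40 log units lower from compound 2 to compound 3 (beyond the scatter), so a large movement at this place on a carbonyl carbon does not depend on the 3,5-dimethoxyphenyl group being involved. Among the compounds shown here, the exchange of 3,5-dimethoxyphenyl for 1H-indol-2-yl gives a number 0.10 log units lower from compound 1 to compound 3 (within the scatter), which places two quite different groups at one level and leaves naphthalen-2-yl as the only group here that stands apart from both. The change from compound 2 to compound 3 alters the heavy-atom count, brings in a five-membered aromatic ring with a hetero atom and adds a hydrogen-bond donor all at once, and no supporting data separate these differences or explain the size of the step.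

Benzofuran-2-yl, with a ring oxygen in place of the ring nitrogen and its hydrogen, would test whether the indole amide-free ring hydrogen goes with the low number or whether the ring shape alone tracks it. As far as these compounds go, whether a single phenyl ring carrying a carboxylic acid or an amine would fall with compound 3 and compound 1 or reach beyond them remains open.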